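Phenylsulfonyl series: bromo substitution on the pendant phenyl

The source may report more compounds than this note shows. Statements on the series, on what has been measured and on what is new or still open speak of the compounds shown alone.

Measured compounds:
compound 1 `Cc1ccc(-c2c(S(=O)(=O)c3ccccc3)cnc3cc(C)nn23)cc1` — 25.8%
compound 2 `Cc1ccc(-c2c(S(=O)(=O)c3ccccc3)cnc3cc(-c4ccccc4)nn23)cc1` — 42.5%

In a functional assay on the whole organism for inhibition, with Mus musculus as the target, with a stated time of 1 h, at a dose of 50 mg/kg by the oral route (a higher number here means more inhibition at the dose given (going by the name of the read-out), a lower number less inhibition), compound 1 gives 25.8% and compound 2 gives 42.5%. Compound 2 stands highest of the two numbers recorded, its nearest neighbour being compound 1, the gap a number 16.7 percentage points higher from compound 1 to compound 2 (beyond the scatter) lying beyond the scatter. Compound 3 `Cc1ccc(-c2c(S(=O)(=O)c3ccccc3)cnc3cc(-c4ccc(Br)cc4)nn23)cc1` is not yet measured in this assay. It differs from compound 2 by bromo in place of hydrogen on an aromatic carbon; cut one bond further out, the change reads phenyl to 4-bromophenyl. Among the compounds with values here, the only measured step, a number 16.7 percentage points higher from compound 1 to compound 2 (beyond the scatter), concerns the exchange of methyl for phenyl at that position and does not speak to a halogen added to the phenyl itself. Within the data shown here, no measured step therefore bears directly on the change to compound 3, and no movement beyond the scatter is expected. For compound 3 the estimate in this assay is 45%, with a range of 25% to 65%, corresponding to an expected step of a number 2.5 percentage points higher from compound 2 to compound 3 (within the scatter).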

Compound 3, a percentage reported as inhibition, in the whole organism at one dose (the size of the read-out at that dose, not a potency): 74.1%
Compound 3: middle estimate off by 29.1 percentage points, on the low side; the whole stated range lies below it.
By their numbers in this assay, from the lowest: compound 1; then compound 2; then compound 3.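

The phenyl at this position can still be improved by substitution: in this assay, bromo in place of hydrogen, on an aromatic carbon para to a large group, gives a number 31.6 percentage points higher from compound 2 to compound 3 (beyond the scatter). The earlier exchange of methyl for phenyl gave only a number 16.7 percentage points higher from compound 1 to compound 2 (beyond the scatter), so a single added heavy atom on the phenyl produces a large step where the whole new ring produced a modest one, and 4-bromophenyl in place of methyl amounts to a number 48.3 percentage points higher from compound 1 to compound 3 (beyond the scatter). No available data account for this gain.

From the compounds shown here alone, whether the gain is specific to bromo stays open, as a chloro, methoxy or amino group at the same place would have to show. Whether the same substitution carries over when the phenylsulfonyl or the 4-methylphenyl group is changed also remains unresolved.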